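The source may report more compounds than this note shows. Statements on the series, on what has been measured and on what is new or still open speak of the compounds shown alone.

Measured so far:
- compound 1, `Cc1cc(NC(=O)CN2CCC(c3cccc[n+]3[O-])CC2)ccc1F`: 18 nM
- compound 2, `Cc1cccc(NC(=O)CN2CCC(c3ccccc3F)CC2)c1`: 1 nM

In a functional assay on HEK293 cells for agonist activity at D(4) dopamine receptor (Homo sapiens), read by FLIPR (on this read-out lower numbers stand for an effect already at smaller amounts and higher numbers for an effect only at larger amounts of compound), compound 1 gives 18 nM, the higher of the two numbers recorded; compound 2 gives 1 nM, a lower number by a margin beyond the usual scatter. Going by the values given here, no pair of compounds differing in a single place has been measured, so no single-step comparison is available in this assay.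

Compound 3, `O=C(CN1CCC(c2cccc[n+]2[O-])CC1)Nc1cccc(Cl)c1Cl`, is not yet measured. It differs from compound 1 by one change: 2,3-dichlorophenyl in place of 4-fluoro-3-methylphenyl on an amide-type nitrogen. The shared core, with its carbonyl, the amide hydrogen and the charged ring, is untouched.

Among the compounds with values here, with no measured step of this kind to lean on, the expectation for compound 3 is a small move toward a lower number, of a size that may well stay within the scatter: a 1.5-fold lower number from compound 1 to compound 3 (0.18 log units; within the scatter). Compound 3 is accordingly estimated at 12 nM in this assay, with a range from 3 nM to 50 nM.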

Compound 3, half-maximal effective concentration: 180 nM
The estimate for compound 3 lay 15-fold (1.18 log units) below the measured number, outside the stated range (above it).
By their numbers in this assay, from the lowest: compound 2; then compound 1; then compound 3.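

In this assay, the group on the amide-type nitrogen proves to be a sensitive place in the core of compound 1: 2,3-dichlorophenyl in place of 4-fluoro-3-methylphenyl gives a 10-fold higher number from compound 1 to compound 3 (1.00 log units; beyond the scatter) in a single change. The leaving and entering groups have the same count of heavy atoms and the same carbon-only aromatic ring, so this step arises with those counted features unchanged. No measured evidence bears on what lies behind the step.

The compounds shown leave open whether the step follows from the two chlorines together or from one of them, and whether the fluorine or the methyl of compound 1 matters more to its lower number. An unsubstituted phenyl or a cyclohexyl on the same nitrogen, with the core of compound 1 kept, would help to separate these readings.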